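The compounds below may be only part of what the source reports. "The series", "measured", "known", "first", "only" and "open" are said of these compounds alone.

Measured so far:
- compound 1 `CCc1ccc(-c2nc(N)c3cc(Cc4ccccc4)sc3n2)o1`: 223 nM
- compound 2 `C=C(c1ccccc1)c1cc2c(N)nc(-c3cccc(C#N)c3)nc2s1`: > 1000 nM
- compound 3 `N#Cc1cccc(-c2nc(N)c3cc(C4(c5ccccc5)CC4)sc3n2)c1`: > 610 nM

Among the compounds with values here, in a functional assay on CHO-K1 cells for antagonist activity at adenosine receptor A1 (Homo sapiens), read by a beta-galactosidase reporter and cAMP accumulation, with stated times of 15 min and 6 h (a lower number here means a stronger inhibitor, a higher number a weaker inhibitor), compound 1 gives 223 nM, the only real number among the three. Compound 2 reaches only a limit, > 1000 nM. Compound 3 likewise reaches only a limit, > 610 nM. Within the data shown here, the single one-place step, a step that the two limits leave unreadable from compound 2 to compound 3, is unreadable because the limit of > 1000 nM in this assay, at which 1 of the 3 values shown sits, and the limit of > 610 nM in this assay, at which 1 of the 3 values shown sits, sit at its two ends, so it gives no size.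

Compound 4 `N#Cc1cncc(-c2nc(N)c3cc(Cc4ccccc4)sc3n2)c1` is not yet measured in this assay. It differs from compound 1 by 5-cyanopyridin-3-yl in place of 5-ethylfuran-2-yl on an aromatic carbon. No measured step touches this position, and the one measured step is unreadable, so nothing shown sets a size for the exchange. The expectation therefore rests on compound 1 alone: the step of a 1.8-fold higher number from compound 1 to compound 4 (0.25 log units; within the scatter) is expected to stay within the scatter, with a wide range. Compound 4 is estimated at 400 nM, between 120 nM and 1500 nM.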

Compound 4, inhibition constant: 1160 nM
Beside the measured number, compound 4's estimate is 2.9-fold (0.46 log units) below it; measured number inside the range.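

In this assay, within the data shown here, the exchange of 5-ethylfuran-2-yl for 5-cyanopyridin-3-yl, on the aromatic carbon between two ring nitrogen atoms, gives a 5.2-fold higher number from compound 1 to compound 4 (0.72 log units; beyond the scatter) and is the first readable step. This position is therefore not indifferent to the group it carries, with the rest of compound 1 held fixed. Nothing measured here accounts for the size of this step.

Open, going by these compounds, is which part of the exchange carries the step, since the six-membered ring, the ring nitrogen and the nitrile enter together, and whether a plain phenyl or a 5-methylfuran-2-yl would fall nearer compound 1 or compound 4. The step from compound 2 to compound 3 stays unreadable, so the other varied position gives no size, and an amine or a carboxylic acid there remains an open case.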